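The compounds below may be only part of what the source reports. "The series", "measured", "known", "first", "only" and "open" are said of these compounds alone.

Measured so far:
- compound 1 `COc1cc(C)[nH]c(=O)c1CN1CCc2c(Cl)cc(-c3c(C)noc3C)c(Cl)c2C1=O`: 70 uL/min
- compound 2 `Cc1cc(C)c(CN2CCc3c(Cl)cc([C@H](CO)[C@@H]4CCCO4)c(Cl)c3C2=O)c(=O)[nH]1`: 37.6 uL/min
- compound 3 `Cc1cc(C)c(CN2CCc3c(Cl)cc(C(CO)C4CCOC4)c(Cl)c3C2=O)c(=O)[nH]1`: 20 uL/min; 25.9 uL/min (2 entries)

In an ADME assay on microsomes from liver (Homo sapiens) for metabolic stability, read by LC-MS, using NADPH, with stated times of 10 min and 45 min, tested at 1 uM (on this read-out higher numbers stand for fast clearance and lower numbers for slow clearance), compound 2 gives 37.6 uL/min, the lower of the two single numbers in the set; the nearest neighbour is compound 1, whose number is within the usual scatter of that of compound 2, so no order between the two can be claimed. Compound 3 stands apart with several entries the several entries of compound 3 in this assay, 20 uL/min; 25.9 uL/min (2 entries) and no single number.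

The step under study goes from compound 2 to compound 4 `Cc1cc(C)c(CN2CCc3c(Cl)cc(-c4c(C)noc4C)c(Cl)c3C2=O)c(=O)[nH]1`, not yet measured in this assay. The change: a group of 7 heavy atoms (5 carbon, 1 nitrogen, 1 oxygen; one five-membered aromatic ring with 2 hetero atoms) in place of a group of 8 heavy atoms (6 carbon, 2 oxygen; one five-membered non-aromatic ring with 1 hetero atom), on an aromatic carbon. Within the data shown here, no measured pair in the set carries this change alone, so its size is not known from data. The group that enters, 3,5-dimethyl-1,2-oxazol-4-yl, is also present in compound 1, and that compound sits at the higher end of the numbers seen, though still within the scatter of compound 2.

The expectation for compound 4 is a modest move toward faster clearance, with the step from compound 2 to compound 4 estimated as a 1.6-fold higher number from compound 2 to compound 4 (0.20 log units; within the scatter), at the edge of the scatter. Compound 4 is therefore estimated at 60 uL/min, in a range from 30 uL/min to 120 uL/min.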

Compound 4, intrinsic clearance in a liver preparation (reported as CLH), per the amount of preparation that the assay uses: 107 uL/min
Beside the measured number, compound 4's estimate is 1.8-fold (0.25 log units) below it; measured number inside the range.
By their numbers in this assay, from the lowest: compounds 2, 1 and 4 (each within the scatter of the next, the first and the last beyond it).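

In this assay the aromatic carbon that carries the changing group responds to the exchange: 3,5-dimethyl-1,2-oxazol-4-yl in place of the group with the five-membered non-aromatic ring gives a 2.8-fold higher number from compound 2 to compound 4 (0.45 log units; beyond the scatter), and this step lies beyond the scatter. With 3,5-dimethyl-1,2-oxazol-4-yl kept, methyl in place of methoxy on an aromatic carbon gives a 1.5-fold higher number from compound 1 to compound 4 (0.18 log units; within the scatter), so no order can be claimed for that second change. No measurement shown gives a cause for the larger step.

As far as these compounds go, the five-membered non-aromatic ring and the hydroxy-bearing chain leave together, so their separate shares in the step remain open. Also open, from the compounds shown here alone, is how an amine or a carboxylic acid on this aromatic carbon would read in this assay.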